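From fluoro to nitro on the aromatic ring of compound 2

The source may hold more compounds than are shown below. What is called first, only, known or untested is meant among the compounds shown, and "the series" means these compounds.

Measured so far in a functional assay on K562 cells (Homo sapiens) for antiproliferative activity, read by MTT assay, with a stated time of 6 days; a higher number here means a weaker inhibitor, a lower number a stronger inhibitor:
Compound 1 `O=C1C=C[C@@H](OCc2ccccc2)[C@@H]([C@@H](COC(=O)/C=C/c2ccccc2)OCc2ccccc2)O1`: 1590 nM
Compound 2 `O=C1C=C[C@@H](OCc2ccccc2)[C@@H]([C@@H](COC(=O)/C=C/c2ccc(F)cc2)OCc2ccccc2)O1`: 1010 nM

Compound 2 and compound 1 share one core and differ only on the aromatic ring at the far end of the ester, where fluoro replaces hydrogen; the step of a 1.6-fold lower number from compound 1 to compound 2 (0.20 log units; within the scatter) keeps the two numbers within the scatter of each other, so compound 2 cannot be ranked apart from compound 1 in this assay.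

Compound 3 `O=C1C=C[C@@H](OCc2ccccc2)[C@@H]([C@@H](COC(=O)/C=C/c2ccc([N+](=O)[O-])cc2)OCc2ccccc2)O1` changes that same ring once more: nitro in place of fluoro on an aromatic carbon. For the measured compounds named here, no measured pair shows this exchange, and the one step that touches the same position was small. The expectation is therefore a step of a 1.1-fold lower number from compound 2 to compound 3 (0.05 log units; within the scatter), not beyond the scatter. For compound 3 the estimated value in this assay is 900 nM, with a range from 400 nM to 2500 nM.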

Compound 3, half-maximal inhibitory concentration: 1270 nM
Compound 3: middle estimate off by 1.4-fold (0.15 log units), on the low side; the range from low to high includes it.
By their numbers in this assay, from the lowest: compounds 2, 3 and 1 (each within the scatter of the next).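

In this assay, the aromatic carbon para to a large group now carries hydrogen, fluoro or nitro, and nitro in place of fluoro gives a 1.3-fold higher number from compound 2 to compound 3 (0.10 log units; within the scatter), while nitro in place of hydrogen gives a 1.3-fold lower number from compound 1 to compound 3 (0.10 log units; within the scatter). Although nitro brings hydrogen-bond acceptors that fluoro and hydrogen lack, compounds 1, 2 and 3 cannot be ranked apart, so these three groups show no measurable difference here. No outside measurement bears on this result.

From the compounds shown here alone, whether an amine or a carboxylic acid on this same carbon would give a step beyond the scatter remains open. The compounds shown also leave open how the numbers respond to changes elsewhere in the shared core, since all three differ only on this one aromatic carbon.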